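Removing the ether side chain from compound 3

The compounds below may be only part of what the source reports. "The series", "measured", "known", "first", "only" and "open" are said of these compounds alone.

In a functional assay for inhibition (a higher number here means a weaker inhibitor, a lower number a stronger inhibitor), compound 1 `CC(C)(C)c1cc(-c2cc(=O)c3ccc(OCC(=O)N4CCN(Cc5ccccc5)CC4)cc3o2)cc(C(C)(C)C)c1O` gives 3000 nM, compound 2 `CC(C)(C)c1cc(-c2cc(=O)c3ccc(OCc4ccc5ccccc5n4)cc3o2)cc(C(C)(C)C)c1O` gives 3000 nM and compound 3 `CCOC(=O)COc1ccc2c(=O)cc(-c3cc(C(C)(C)C)c(O)c(C(C)(C)C)c3)oc2c1` gives 3000 nM, so compound 3 stands level with the other two. Compound 4 `CC(C)(C)c1cc(-c2cc(=O)c3ccccc3o2)cc(C(C)(C)C)c1O` has hydrogen in place of (ethoxycarbonyl)methoxy on an aromatic carbon. Going by the values given here, the one measured step between compounds differing in one place is no change at the digits printed from compound 2 to compound 3 (within the scatter). Among the compounds with values here, no measured compound lacks the group on this aromatic carbon, so the evidence is indirect and the direction of any shift is open. Expected in this assay is no shift beyond the scatter, with the estimated step being no change at the digits printed from compound 3 to compound 4 (within the scatter). For compound 4 the estimated value is 3000 nM, with an expected range of 1000 nM to 9000 nM.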

Compound 4, half-maximal inhibitory concentration: 3000 nM
Compound 4: middle estimate and measured number agree at the digits printed, and the stated range covers the measured number.
By their numbers in this assay, from the lowest: compounds 1, 2, 3 and 4 (each within the scatter of the next).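

In this assay hydrogen in place of (ethoxycarbonyl)methoxy on this aromatic carbon gives no change at the digits printed from compound 3 to compound 4 (within the scatter) and hydrogen in place of (quinolin-2-yl)methoxy gives no change at the digits printed from compound 2 to compound 4 (within the scatter) so the unsubstituted position reads level with both ethers. Neither side chain therefore shows any measurable gain over hydrogen at this position. No supporting data bear on why this position stays flat.

Still open, going by these compounds, is whether a carboxylic acid or a primary amine on this carbon would separate from hydrogen. Also open, on these data alone, is whether a change elsewhere on the shared core would move the value.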